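The source may hold more compounds than are shown below. What is called first, only, known or untested is meant among the compounds shown, and "the series" means these compounds.

Compound 1 `Fc1ccc2nc(-c3cc(-c4ccccc4)n(-c4ccccc4)n3)ccc2c1` is the parent of this set; in an ADME assay on Huh-7 cells (Homo sapiens) for cytotoxicity, read by XTT assay, with a stated time of 3 days, tested at 200 uM (a lower number here means a stronger effect, a higher number a weaker effect of the compound at the concentration tested), compound 1 gives 115%. Compound 2 `Fc1ccc(-c2cc(-c3ccc4cc(F)ccc4n3)nn2-c2ccccc2)cc1` carries one change against it, (fluoro in place of hydrogen on an aromatic carbon), and in this assay compound 2 gives 89.7%, so the step of a number 25.3 percentage points lower from compound 1 to compound 2 (beyond the scatter). Compound 3 `Fc1ccc(-n2nc(-c3ccccc3)cc2-c2ccc3cc(F)ccc3n2)cc1` has the same kind of substituent on a different ring; how its core differs from that of compound 1 is not broken down here. In this assay compound 3 gives 91.6%, a value within the scatter of compound 2. Compound 4 `Fc1ccc(-c2cc(-c3ccc4cc(F)ccc4n3)n(-c3ccc(F)cc3)n2)cc1` is not yet measured; it differs from compound 3 by fluoro in place of hydrogen on an aromatic carbon, the same change as from compound 1 to compound 2. Within the data shown here, a comparable downward step is expected, a number 19.6 percentage points lower from compound 3 to compound 4 (beyond the scatter), resting on the single precedent a number 25.3 percentage points lower from compound 1 to compound 2 (beyond the scatter). For compound 4 the estimate is therefore 72%, with a range from 45% to 100%.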

Compound 4, a percentage reported as activity, at one concentration (the size of the read-out at that concentration, not a potency): 86.5%
For compound 4 the middle estimate is 14.5 percentage points below the measured one; low and high end bracket the measured number.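

In this assay, phenyl to 4-fluorophenyl gives a number 5.1 percentage points lower from compound 3 to compound 4 (within the scatter). The size of this step does not carry unchanged from one core to the other: the same change on two cores in this assay, a number 25.3 percentage points lower (beyond the scatter) from compound 1 to compound 2 and a number 5.1 percentage points lower (within the scatter) from compound 3 to compound 4, 20.2 percentage points apart, beyond the scatter of two such steps

Among these compounds, with only one pair on each core, this shows that the same fluoro change need not give the same step on another core, but it does not show which feature of the core sets the size, and it gives no rule for a further core. The compounds shown leave open whether a group other than fluoro in the same place, such as chloro, methoxy or an amine, would give a step of similar size. They also leave open how such groups would compare between the two cores.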